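The compounds below may be only part of what the source reports. "The series", "measured", "known", "first", "only" and "open" are said of these compounds alone.

Among the compounds with values here, in a functional assay on NCI-H522 cells (Homo sapiens) for cytotoxicity, with a stated time of 3 days (a higher number here means a weaker inhibitor, a lower number a stronger inhibitor), compound 2 `C#Cc1nc2ccccc2o1` gives 1260 nM, the only actual number so far. Compound 1 `C=Cc1nc2ccccc2o1` reads > 40000 nM, which is a limit of the assay. Compound 3 `Brc1nc2ccccc2o1` changes the same carbon of the shared core: bromo in place of ethynyl on an aromatic carbon. Within the data shown here, only one measured step bears on this, the large change of ethynyl in place of vinyl, an at least 31-fold lower number from compound 1 to compound 2 (1.50 log units; beyond the scatter). Since compound 3 also loses the ethynyl, a higher number is expected in this assay, though bromo is not vinyl and the size remains uncertain. The expected change is a 6.3-fold higher number from compound 2 to compound 3 (0.80 log units; beyond the scatter). For compound 3 the estimated value is 8000 nM, expected between 2000 nM and 30000 nM.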

Compound 3, half-maximal inhibitory concentration: > 40000 nM
Compound 3 was reported as a limit; the forecaster's own chance of this, stated with the estimate: 25%; middle value at least 5.0-fold (0.69 log units) away from the limit.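

In this assay, bromo in place of ethynyl on this aromatic carbon gives an at least 31-fold higher number from compound 2 to compound 3 (1.50 log units; beyond the scatter). The loss on leaving ethynyl is therefore not tied to vinyl alone: of the three groups shown at this carbon, only the ethynyl of compound 2 gives an actual number. The step between compound 1 and compound 3 cannot be read, because both values are limits: the limit of > 40000 nM in this assay, at which 2 of the 3 values shown sit.

The compounds shown leave open whether any other group at this carbon, such as a nitrile, an amine or a longer alkyne chain, gives a measurable number.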